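Working notes: cytotoxicity across the shared core

This account rests on a few compounds, and the source may have more. Where it says the series, first, only, none or still open, it means among the compounds named here.

Compound 1 `Cc1ccc(OCc2cn(-c3ccc(S(=O)(=O)N4CCc5ccccc5C4)cc3)nn2)cc1` — > 50 ug/mL
Compound 2 `COc1cc2c(cc1OC)CN(S(=O)(=O)c1ccc(-n3cc(COc4ccc([N+](=O)[O-])cc4)nn3)cc1)CC2` — > 50 ug/mL
Compound 3 `O=S(=O)(c1ccc(-n2cc(COc3ccccc3)nn2)cc1)N1CCc2ccccc2C1` — > 50 ug/mL

In an ADME assay on Vero cells (Chlorocebus sabaeus) for cytotoxicity, with a stated time of 4 days (on this read-out higher numbers stand for weaker inhibition and lower numbers for stronger inhibition), compound 1 gives > 50 ug/mL, which is a limit of the assay and not a number. Compound 2 gives > 50 ug/mL in this assay, again a limit. Compound 3 gives > 50 ug/mL, also a limit. Among the compounds with values here, the one single-point step measured so far, a step that the two limits leave unreadable from compound 1 to compound 3, therefore cannot be read for size. Compound 2 stands where every measured value stands, at the limit of > 50 ug/mL in this assay, at which 3 of the 3 values shown sit; nothing separates it from compound 1 or compound 3 on the numbers shown.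

Compound 4 `COc1cc2c(cc1OC)CN(S(=O)(=O)c1ccc(-n3cc(COc4ccccc4)nn3)cc1)CC2` has not been measured in this assay. It differs from compound 2 by hydrogen in place of nitro on an aromatic carbon. Within the data shown here, no measured step bears on this change, and the only measured step is unreadable, so no size or direction beyond the scatter can be anticipated. The expected step is a number no higher from compound 2 to compound 4 (the limit leaves the size open). Compound 4 is estimated at 50 ug/mL, within 25 ug/mL to 200 ug/mL, and is expected to return a limit rather than a number.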

Compound 4, half-maximal inhibitory concentration: > 50 ug/mL
Compound 4: no number, only a limit; the forecaster's own chance of this, stated with the estimate: 85%; the middle value sits exactly at the limit.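

In this assay compound 4 gives > 50 ug/mL, which is a limit and not a number. Compound 2 also sits at a limit, so no step can be read between compound 2 and compound 4. The compounds shown leave open whether any change on the shared core would give a number rather than a limit: the limit of > 50 ug/mL in this assay, at which 4 of the 4 values shown sit.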